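Adding a Nitro Group: What Tolerance Might Follow

The source may hold more compounds than are shown below. What is called first, only, known or untested is meant among the compounds shown, and "the series" means these compounds.

Measured so far:
compound 1, `COc1ccc(-c2nc3cc(Cl)c(Cl)cc3[nH]2)cc1`, 1000 nM
compound 3, `CC(=O)Nc1ccc(-c2nc3ccccc3[nH]2)cc1`, 100000 nM
compound 2, `CC(=O)Nc1ccc(-c2nc3cc([N+](=O)[O-])ccc3[nH]2)cc1`, a limit of the assay: > 100000 nM

In an ADME assay on MT4 cells (Homo sapiens) for cytotoxicity, read by MTT assay, with a stated time of 96 h (a higher number here means that more compound is tolerated, a lower number that less compound is tolerated), compound 1 gives 1000 nM, the lowest of the two numbers shown, while compound 3 gives 100000 nM. For compound 2 the result > 100000 nM is a limit, not a number, as noted in the limit of > 100000 nM in this assay, at which 1 of the 3 values shown sits. The difference between the cores of compound 1 and compound 3 is not broken down here. From compound 3 to compound 2 the change is nitro in place of hydrogen on an aromatic carbon, and the step is a number no lower from compound 3 to compound 2 (the limit leaves the size open). Compound 4, `COc1ccc(-c2nc3cc(Cl)c(Cl)cc3[nH]2)c([N+](=O)[O-])c1`, has not been measured; from compound 1 it carries nitro in place of hydrogen on an aromatic carbon, the same kind of change, though its place is ortho to a large group and meta to a methoxy group rather than meta and para to a fused ring. Since a number no lower from compound 3 to compound 2 (the limit leaves the size open) shows no drop, compound 4 is expected to stay near compound 1 or above it. The expected step is a 2.5-fold higher number from compound 1 to compound 4 (0.40 log units; beyond the scatter). Compound 4 is estimated at 2500 nM, within 700 nM to 20000 nM.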

Compound 4, half-maximal cytotoxic concentration: 2000 nM
For compound 4 the middle estimate is 1.3-fold (0.10 log units) above the measured one; low and high end bracket the measured number.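

In this assay, nitro in place of hydrogen on an aromatic carbon gives a 2.0-fold higher number from compound 1 to compound 4 (0.30 log units; within the scatter), so on the core of compound 1 the change brings no step beyond the scatter. Set beside the earlier case, the two cores compare as follows: the same change on two cores in this assay, a number no lower (the limit leaves the size open) from compound 3 to compound 2 and a 2.0-fold higher number (0.30 log units; within the scatter) from compound 1 to compound 4; the limit leaves it open whether they differ. Among the compounds shown here, neither core shows a lower number with the nitro group, but this rests on only two pairs and does not show that the change has the same size on both cores, nor that it would hold on any further core.

The compounds shown leave open whether the reading in this assay would stay the same with the nitro group in another place on the core of compound 1, where it would no longer be ortho to a large group and meta to a methoxy group. They also leave open what an amine or a carboxylic acid in the same place would give on either core.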